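Swapping the Halophenyl Group on Compound 3

The compounds below may be only part of what the source reports. "The series", "measured", "known", "first", "only" and "open" are said of these compounds alone.

Measured compounds:
compound 1 `Cc1cc(=O)c2c(O)cc(O)c([C@H]3CCN(C)C[C@H]3OC(=O)c3ccco3)c2o1` — 33%
compound 2 `CCOC(=O)N1CCN(Cc2c(O)c([C@H]3CCN(C)C[C@H]3O)c3oc(C)cc(=O)c3c2O)CC1` — 18%
compound 3 `Cc1oc2c([C@H]3CCN(C)C[C@H]3O)c(O)cc(O)c2c(=O)c1C(O)c1ccccc1Br` — 7%

In a functional assay on Caco-2 cells (Homo sapiens) for inhibition, read by MTT assay, with a stated time of 48 h, tested at 10 uM (a lower number here means less inhibition of growth, a higher number more inhibition of growth at the concentration tested), compound 3 gives 7%, the lowest of the three numbers; compound 2 lies nearest, and even that gap is beyond the usual scatter, while compound 1 stands furthest away. Compound 4 `Cc1oc2c([C@H]3CCN(C)C[C@H]3O)c(O)cc(O)c2c(=O)c1C(O)c1ccc(F)cc1` differs from compound 3 in one place: 4-fluorophenyl in place of 2-bromophenyl on a saturated chain carbon bound to an aromatic carbon and an oxygen on a saturated carbon. For the measured compounds named here, no pair of measured compounds shows what such a swap does, so the size of the step is uncertain; a small step is expected, most likely upward but not beyond the scatter. The expected step is a number 5 percentage points higher from compound 3 to compound 4 (within the scatter). For compound 4 the estimate in this assay is 12%, with a range from 0% to 30%.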

Compound 4, percent growth inhibition at one concentration: 11%
Compound 4: middle estimate off by 1 percentage points, on the high side, and the stated range covers the measured number.
By their numbers in this assay, from the lowest: compounds 3, 4 and 2 (each within the scatter of the next, the first and the last beyond it); then compound 1.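

In this assay, for the compounds shown here, the exchange of 2-bromophenyl for 4-fluorophenyl on this saturated chain carbon gives a number 4 percentage points higher from compound 3 to compound 4 (within the scatter), the only step that can be read at this position. The two halophenyl groups therefore cannot be told apart here, although both the halogen and its place on the ring differ. Nothing measured bears on why the two compounds read alike.

As far as these compounds go, the separate contributions of the halogen and its place on the ring remain open. So does whether an amine or a carboxylic acid on the phenyl ring would move the number beyond the scatter.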